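Swapping the amine group on compound 1

This account rests on a few compounds, and the source may have more. Where it says the series, first, only, none or still open, it means among the compounds named here.

Values in a functional assay on K562 cells (Homo sapiens) for inhibition, read by trypan blue exclusion, with a stated time of 72 h; on this read-out higher numbers stand for weaker inhibition and lower numbers for stronger inhibition:
- Compound 1 `COc1ccc(Nc2ncc3cc(S(=O)(=O)c4ccc(C)cc4)c(=O)n(C)c3n2)cc1`: 75000 nM
- Compound 2 `COc1ccc(Nc2ncc3cc(S(=O)(=O)c4ccc(Cl)cc4)c(=O)n(C)c3n2)cc1`: 15000 nM
- Compound 3 `Cn1c(=O)c(S(=O)(=O)c2ccc(F)cc2)cc2cnc(Nc3ccc4[nH]ncc4c3)nc21`: 10000 nM

Among these three, compound 1 has the highest number at 75000 nM, which makes it the weakest inhibitor of the group in this assay. Compound 4 `Cc1ccc(S(=O)(=O)c2cc3cnc(Nc4cccc5cccnc45)nc3n(C)c2=O)cc1` has not yet been measured. It keeps the core of compound 1 but exchanges one group: quinolin-8-yl in place of 4-methoxyphenyl on a nitrogen on an aromatic ring. Put simply, quinolin-8-yl stands in place of 4-methoxyphenyl on a nitrogen.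

Among the measured compounds shown here, no measured step makes this exact change. For the measured compounds named here, the only measured single change, a 5.0-fold lower number from compound 1 to compound 2 (0.70 log units; beyond the scatter), puts chloro in place of methyl on an aromatic carbon, so it shows the size a single change can reach here but says nothing about this group. Compound 3 at 10000 nM is only a loose guide, since it differs from compound 1 in that place and in a second one as well.

With so little to go on, only a small move towards stronger inhibition is expected, and it may not rise above the scatter. The expected step is a 1.9-fold lower number from compound 1 to compound 4 (0.27 log units; within the scatter). For compound 4 the estimated value is 40000 nM, with an expected range from 10000 nM to 150000 nM.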

Compound 4, half-maximal inhibitory concentration: 10000 nM
Beside the measured number, compound 4's estimate is 4.0-fold (0.60 log units) above it; low and high end bracket the measured number.
By their numbers in this assay, from the lowest: compounds 3, 4 and 2 (each within the scatter of the next); then compound 1.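

In this assay putting quinolin-8-yl in place of 4-methoxyphenyl on the nitrogen gives a 7.5-fold lower number from compound 1 to compound 4 (0.88 log units; beyond the scatter) and so shows that the group on this nitrogen affects the read-out. Among the compounds shown here, the only earlier single change, chloro in place of methyl on an aromatic carbon, gave a 5.0-fold lower number from compound 1 to compound 2 (0.70 log units; beyond the scatter) and left this nitrogen untouched, so two different places on compound 1 have now each moved the number beyond the scatter. The result also shows that a group with a second ring, one of which carries a ring nitrogen, can stand at this place with the number going down rather than up, although compound 4 at 10000 nM is a single example.

As far as these compounds go, it remains open whether the step comes from the second ring or from the ring nitrogen, and whether a simpler replacement on the nitrogen, such as a phenyl ring carrying a carboxylic acid or a morpholine, would move the number in the same direction. Nothing shown here gives a reason for the step.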